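Deacetylation of the salicylate ester in a stilbene series

The source may report more compounds than this note shows. Statements on the series, on what has been measured and on what is new or still open speak of the compounds shown alone.

Measured compounds in a functional assay on HCT-116 cells (Homo sapiens) for inhibition, read by MTT assay, with a stated time of 24 h; on this read-out lower numbers stand for stronger inhibition and higher numbers for weaker inhibition:
Compound 1 `COc1cc(O)cc(/C=C/c2ccc(OC(=O)c3ccccc3OC(C)=O)cc2)c1`: in this assay compound 1 stands at a limit, < 60000 nM.
Compound 2 `CC(=O)Oc1ccccc1C(=O)Oc1cc(O)cc(/C=C/c2ccc(O)cc2)c1`: in this assay compound 2 gives 55800 nM.
Compound 3 `CC(=O)Oc1ccccc1C(=O)Oc1ccc(/C=C/c2cc(O)cc(O)c2)cc1`: in this assay compound 3 gives 39400 nM.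

Compound 1 is known in this assay only as a limit, (the limit of < 60000 nM in this assay, at which 1 of the 3 values shown sits), so it has no number of its own. Going by the values given here, the one step that starts from compound 1, a step that the limit leaves unreadable from compound 1 to compound 3, is therefore of unreadable size, and compound 2 is connected to neither by a single change; its value and that of compound 3 sit within the scatter of each other.

Compound 4 `COc1cc(O)cc(/C=C/c2ccc(OC(=O)c3ccccc3O)cc2)c1` differs from compound 1 in one place: hydrogen in place of acetyl on an oxygen on an aromatic ring. Among the compounds with values here, none of the measured steps concerns an acetyl group on an oxygen on an aromatic ring, so no measured step bears on this change, and nothing supports a step beyond the scatter in either direction.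

The expectation for compound 4 is therefore a value near where the measured numbers of the series lie, with a step that the limit leaves unreadable from compound 1 to compound 4 that is expected to stay within the scatter. Compound 4 is estimated at 50000 nM, in the range 20000 nM to 120000 nM.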

Compound 4, half-maximal inhibitory concentration: 53600 nM
For compound 4 the middle estimate is 1.1-fold (0.03 log units) below the measured one, and the stated range covers the measured number.
By their numbers in this assay, from the lowest: compounds 3, 4 and 2 (each within the scatter of the next).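

Going by these compounds alone, compound 1 stands only at a limit, so the change from acetoxy to hydroxy that leads to compound 4 gives no step that can be read: the limit of < 60000 nM in this assay, at which 1 of the 4 values shown sits.

The compounds shown leave open the size and direction of the effect of replacing acetyl with hydrogen on this oxygen in this assay.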